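Swapping a methyl for a tert-butyl on a side-chain ether

This account rests on a few compounds, and the source may have more. Where it says the series, first, only, none or still open, it means among the compounds named here.

Compound 1 `COCC(C)Oc1cccc2ccc(N)nc12` carries a 1-(methoxymethyl)ethyl group on an oxygen on its aromatic core. In an assay on cells with melanin-concentrating hormone receptor 1 (Homo sapiens) as the target, read by radioligand binding (a higher number here means a weaker inhibitor, a lower number a stronger inhibitor), compound 1 gives 606 nM, the higher of the two numbers shown. Compound 2 `CCC(C)COc1cccc2ccc(N)nc12` gives 36 nM, so that a 17-fold lower number from compound 1 to compound 2 (1.23 log units; beyond the scatter). Compound 3 `CSCCOc1cccc2ccc(N)nc12` reaches only a limit of the assay, > 2000 nM. Compound 4 `CC(COC(C)(C)C)Oc1cccc2ccc(N)nc12` differs from compound 1 by tert-butyl in place of methyl on an oxygen on a saturated carbon. The step to compound 2 is the closest guide, since there too a larger alkyl group entered and the number fell sharply; the step of an at least 3.3-fold higher number from compound 1 to compound 3 (0.51 log units; beyond the scatter), with sulfur entering, points the other way. For compound 4 a lower number is therefore expected, estimated at 200 nM with a range of 60 nM to 800 nM, which would mean a 3.0-fold lower number from compound 1 to compound 4 (0.48 log units; beyond the scatter).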

Compound 4, half-maximal inhibitory concentration: 306 nM
Compound 4: the middle estimate sits 1.5-fold (0.18 log units) below what was measured, and the stated range covers the measured number.
By their numbers in this assay, from the lowest: compound 2; then compounds 4 and 1 (each within the scatter of the next). At a limit, above all of these: compound 3.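

Putting tert-butyl in place of methyl on this oxygen gives, in this assay, a 2.0-fold lower number from compound 1 to compound 4 (0.30 log units; within the scatter). Among these compounds, every earlier step between these compounds lay beyond the scatter; this is the first that does not, so a much larger group fits at this place without a clear change in the number. No measurement shown here bears on the reason for this result.

Still open, as far as these compounds go, is whether an amine, a carboxylic acid or a cyclohexyl ring at this same place would shift the number. A longer chain in place of tert-butyl is equally untested among these compounds.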